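From Methylamino to Diethylamino: An Expected Step

A few compounds are considered here, and "the series" means these few. Any claim that something is new, unique, unknown or untested is made for them only; others in the source may bear on it.

Compound 1 `CN/C(C)=N/C1=Nc2ccccc2CS1` is the starting point of this story. In a functional assay (strain Wistar) with Rattus norvegicus as the target, read by LDH release (on this read-out lower numbers stand for an effect already at smaller amounts and higher numbers for an effect only at larger amounts of compound), compound 1 gives 0.01 uM, the lowest of the two numbers seen so far. Among the compounds with values here, the only other measured compound, compound 2 `CCCN(CCC)/C(C)=N/C1=Nc2ccc(OC(F)(F)F)cc2CS1`, carries a dipropylamino group and a trifluoromethoxy group where compound 1 has a methylamino group and a hydrogen; in this assay compound 2 gives 0.1 uM, a step up from compound 1 that lies beyond the usual scatter. Within the data shown here, two places change at once between compound 1 and compound 2, so their pair shows only that the doubly altered compound needs more material to produce an effect.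

Compound 3 `CCN(CC)/C(C)=N/C1=Nc2ccccc2CS1` has not yet been measured. It differs from compound 1 in one place: diethylamino in place of methylamino on a carbon with a double bond to nitrogen. Among the measured compounds shown here, no step that changes only this place is known, so the direction is read from compound 2, whose value 0.1 uM stands above that of compound 1. The expected step is a 3.0-fold higher number from compound 1 to compound 3 (0.48 log units; beyond the scatter), toward a higher number, and probably beyond the scatter. Compound 3 is therefore expected at 0.03 uM, within a range of 0.01 uM to 0.1 uM.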

Compound 3, minimum effective concentration: 0.1 uM
Estimate against measurement, compound 3: 3.3-fold (0.52 log units) below, within the range that was stated.
By their numbers in this assay, from the lowest: compound 1; then compounds 2 and 3 (each within the scatter of the next).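

Putting diethylamino in place of methylamino on a carbon with a double bond to nitrogen, with the rest of compound 1 unchanged, gives a 10-fold higher number from compound 1 to compound 3 (1.00 log units; beyond the scatter) in this assay. Within the data shown here, this is the first look at this position on its own, since the earlier pair changed two places at once, and it shows that this change alone is enough to move the number beyond the scatter, so that more compound is needed for an effect. The swap alters two things together, as the entering group has more heavy atoms and, unlike methylamino, no hydrogen-bond donor, and nothing measured here tells which of these matters or why the number rises.

Ethylamino, which keeps a hydrogen on the nitrogen, and dimethylamino, which has none, could help to separate those two differences at this same place. Going by these compounds, the effect of the trifluoromethoxy group alone also remains open, as does whether this single step would hold on a core carrying that group.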